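The source may report more compounds than this note shows. Statements on the series, on what has been measured and on what is new or still open speak of the compounds shown alone.

Of the compounds shown here, three have been measured in a functional assay on OS-RC-2 cells (Homo sapiens) for cytotoxicity, read by MTT assay, with a stated time of 72 h; a lower number here means a stronger inhibitor, a higher number a weaker inhibitor.
Compound 1 `O=C(Nc1ccc(-n2ncc3c(C(F)(F)F)cccc32)cc1)Nc1ccc(Cl)c(C(F)(F)F)c1` gives > 32000 nM, which is a limit of this assay and not a number.
Compound 2 `COc1cccc2c1cnn2-c1ccc(NC(=O)Nc2ccc(Cl)c(C(F)(F)F)c2)cc1` gives 28800 nM.
Compound 3 `O=C(Nc1ccc(-n2ncc3c(C(F)(F)F)cccc32)cc1)Nc1ccc(C(F)(F)F)cc1` gives 4000 nM.

Compound 3 therefore holds the lowest of the two numbers; compound 2 sits higher, beyond the scatter. Compound 4 `O=C(Nc1ccc(-n2ncc3c(Cl)cccc32)cc1)Nc1ccc(C(F)(F)F)cc1` differs from compound 3 by one change: chloro in place of trifluoromethyl on an aromatic carbon. Among the compounds with values here, the only measured step at that same place is an at least 1.1-fold lower number from compound 1 to compound 2 (0.04 log units; that floor lies within the scatter), a swap within the scatter, though the limit of > 32000 nM in this assay, at which 1 of the 3 values shown sits, limits what that step can show. The step of an at least 8.0-fold lower number from compound 1 to compound 3 (0.90 log units; beyond the scatter) concerns another place and does not bear on this change. The expected step is no change at the digits printed from compound 3 to compound 4 (within the scatter), not beyond the scatter. For compound 4 in this assay the estimate is 4000 nM, expected between 1300 nM and 12000 nM.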

Compound 4, half-maximal inhibitory concentration: 4600 nM
Beside the measured number, compound 4's estimate is 1.2-fold (0.06 log units) below it, within the range that was stated.
By their numbers in this assay, from the lowest: compounds 3 and 4 (each within the scatter of the next); then compound 2. At a limit, above all of these: compound 1.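

In this assay, within the data shown here, the swap gives a 1.2-fold higher number from compound 3 to compound 4 (0.06 log units; within the scatter), the only step at this position with a true number at both ends. Chloro, with one heavy atom, and trifluoromethyl, with four, cannot be told apart here. The earlier step at this position starts from compound 1, whose value is a limit and not a number: the limit of > 32000 nM in this assay, at which 1 of the 4 values shown sits.

Still open, from the compounds shown here alone, is how an amine or a carboxylic acid on this aromatic carbon would read. Also open, going by these compounds, is whether chloro and trifluoromethyl stay level with 4-chloro-3-(trifluoromethyl)phenyl on the amide-type nitrogen.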